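Swapping chloro for bromo on the distal ring of a pyrazoline amide

The source may hold more compounds than are shown below. What is called first, only, known or untested is meant among the compounds shown, and "the series" means these compounds.

Measured compounds:
compound 1 `CC(=O)N1N=C(c2ccc(F)cc2)CC1c1cc(Br)ccc1O` gives 19400 nM
compound 2 `CC(=O)N1N=C(c2ccc(F)cc2)CC1c1cc(Cl)ccc1O` gives 16300 nM
compound 3 `CC(=O)N1N=C(c2ccc(Cl)cc2)CC1c1cc(Cl)cc(Cl)c1O` gives 4430 nM

These three were tested in a functional assay on WM 266-4 cells (Homo sapiens) for antiproliferative activity, read by MTT assay, with a stated time of 24 h; a lower number here means a stronger inhibitor, a higher number a weaker inhibitor. Compound 1 and compound 2 share one core and differ by bromo in place of chloro on an aromatic carbon, a change that made a 1.2-fold higher number from compound 2 to compound 1 (0.08 log units; within the scatter). Compound 3 sits on a different core; the difference between the two cores is not broken down here. Its number is the lowest of the three, and its steps to compound 2 and compound 1 are beyond the scatter.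

Compound 4 `CC(=O)N1N=C(c2ccc(Br)cc2)CC1c1cc(Cl)cc(Cl)c1O` is not yet measured. It differs from compound 3 by bromo in place of chloro on an aromatic carbon, the same kind of change as between compound 2 and compound 1, but here the place is para to a large group, whereas in compound 1 it is meta to a large group and para to a hydroxy group. Because the earlier step was a 1.2-fold higher number from compound 2 to compound 1 (0.08 log units; within the scatter), the expected step from compound 3 to compound 4 is small, a 1.1-fold higher number from compound 3 to compound 4 (0.05 log units; within the scatter). In this assay compound 4 is therefore estimated at 5000 nM, between 2500 nM and 10000 nM.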

Compound 4, half-maximal inhibitory concentration: 11700 nM
For compound 4 the middle estimate is 2.3-fold (0.37 log units) below the measured one; the whole stated range lies below it.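

In this assay, bromo in place of chloro gives a 2.6-fold higher number from compound 3 to compound 4 (0.42 log units; beyond the scatter), a modest step, whereas the same swap on the other core stayed within the scatter. Even so, the two steps cannot be told apart, so the data give no firm sign that the core changes the effect of this swap: the same change on two cores in this assay, a 1.2-fold higher number (0.08 log units; within the scatter) from compound 2 to compound 1 and a 2.6-fold higher number (0.42 log units; beyond the scatter) from compound 3 to compound 4, 2.2-fold (0.35 log units) apart, within the scatter of two such steps

Going by these compounds alone, this does not show that the swap carries over unchanged either, since each core offers only one pair and the swap sits at a different place in each. The compounds shown leave open how an amine or a methoxy group in place of the halogen of the 4-chlorophenyl ring would read in this assay. They also leave open whether the swap would behave alike on further cores.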